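Swapping Nitro for Dimethylamino on a Shared Core

A few compounds are considered here, and "the series" means these few. Any claim that something is new, unique, unknown or untested is made for them only; others in the source may bear on it.

In a physicochemical assay for lipophilicity (on this read-out higher numbers stand for higher lipophilicity and lower numbers for lower lipophilicity), compound 3 `C[n+]1ccn(CC[N+](=O)[O-])c1/C=N/O` stands at no result reported. Two relatives on the shared core do have numbers: compound 1 `C[n+]1ccn(CCC#N)c1/C=N/O` gives -3.3, and compound 2 `C[n+]1ccn(CCOCCF)c1/C=N/O` gives -2.62. Among the compounds with values here, the step of a number 0.68 log units higher from compound 1 to compound 2 (beyond the scatter) is the only measured step. Compound 4 `CN(C)CCn1cc[n+](C)c1/C=N/O` differs from compound 3 by dimethylamino in place of nitro on a saturated chain carbon, two bonds along the chain from an aromatic nitrogen. Within the data shown here, no measured step exchanges nitro for dimethylamino, so the one step from compound 1 to compound 2 bears only loosely on this change, showing that a swap at this chain position can move the read-out by a modest amount in either direction. Compound 4 is therefore expected to sit near its relatives, with an estimated -3.3 and a range from -4.2 to -2.4.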

Compound 4, distribution coefficient: -3.06
Beside the measured number, compound 4's estimate is 0.24 log units below it, within the range that was stated.
By their numbers in this assay, from the lowest: compounds 1 and 4 (each within the scatter of the next); then compound 2.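

Dimethylamino on a saturated chain carbon, two bonds along the chain from an aromatic nitrogen, adds a second comparison at this position: in this assay there is a number 0.44 log units lower from compound 2 to compound 4 (beyond the scatter) and a number 0.24 log units higher from compound 1 to compound 4 (within the scatter) on this read-out. Cyano and dimethylamino therefore cannot be told apart here, while 2-fluoroethoxy stands apart from both. Nothing available explains this pattern. Where a carboxylic acid or a longer chain at this position would fall stays open, and so does whether the same pattern would hold on another core.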